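Cytotoxicity notes on compounds 1 to 3

The source may hold more compounds than are shown below. What is called first, only, known or untested is meant among the compounds shown, and "the series" means these compounds.

Measured so far:
compound 1: `CCCCCc1cc(-c2cn([C@H]3C[C@H](OC(C)=O)[C@@H](COC(C)=O)O3)c(=O)[nH]c2=O)on1` — 91.9%
compound 2: `CC(C)(C)c1ccc(Cn2cc(-c3cn([C@H]4C[C@H](O)[C@@H](CO)O4)c(=O)[nH]c3=O)nn2)cc1` — 94.8%

In a functional assay on NUGC-3 cells (Homo sapiens) for cytotoxicity, read by sulforhodamine B assay, tested at 10 uM (a higher number here means more inhibition at the concentration tested (going by the name of the read-out), a lower number less inhibition), compound 1 stands at 91.9%. Compound 2 gives 94.8%, a number that sits within the scatter of compound 1, so the two cannot be ordered. Both measured compounds show strong inhibition at the tested concentration, leaving little room upward.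

Compound 3, `CCCCc1ccc(-c2cc(-c3cn([C@H]4C[C@H](OC(C)=O)[C@@H](COC(C)=O)O4)c(=O)[nH]c3=O)on2)cc1`, differs from compound 1 in one place: 4-butylphenyl in place of pentyl on an aromatic carbon. Within the data shown here, no measured pair shows this change, so nothing about its effect can be drawn from the numbers at hand. Given that compound 1 already sits high in this assay, the step of a number 3.9 percentage points lower from compound 1 to compound 3 (within the scatter) is expected to remain within the scatter, with no direction claimed. Compound 3 is therefore estimated at 88%, with a range from 70% to 97%.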

Compound 3, a percentage reported as inhibition, at one concentration (the size of the read-out at that concentration, not a potency): 39.8%
Compound 3: the middle estimate sits 48.2 percentage points above what was measured, outside the stated range (below it).
By their numbers in this assay, from the lowest: compound 3; then compounds 1 and 2 (each within the scatter of the next).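

Compound 1 and compound 3 show that the position on the aromatic carbon next to the ring nitrogen is not indifferent to its group: in this assay, 4-butylphenyl in place of pentyl gives a number 52.1 percentage points lower from compound 1 to compound 3 (beyond the scatter) on the otherwise unchanged core. The entering group brings a six-membered aromatic ring of carbon only, while hydrogen-bond donors, hydrogen-bond acceptors and net charge stay the same between the two groups. Nothing at hand accounts for the size of this step.

Still open, on these data alone, is whether the step follows the aromatic ring itself or the butyl chain on it, a question that plain phenyl at this position could address. Also open, as far as these compounds go, is how a chain longer than pentyl, or one ending in an amine, would read here.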